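Chain extension on the indole nitrogen of compound 1

The source may report more compounds than this note shows. Statements on the series, on what has been measured and on what is new or still open speak of the compounds shown alone.

Compound 1 `O=C1Nc2ccccc2/C1=C\c1c(Cl)n(Cc2ccccc2)c2ccccc12` gives 64600 nM in a functional assay on cells (Cancer cell lines, Homo sapiens) for cytotoxicity, with a stated time of 48 h (on this read-out lower numbers stand for stronger inhibition of growth and higher numbers for weaker inhibition of growth), the higher of the two numbers recorded; compound 2 `COc1cc2c(/C=C3/C(=O)Nc4ccc(Cl)cc43)c(Cl)n(Cc3cc(OC)c(OC)c(OC)c3)c2cc1C` gives 5500 nM, a gap beyond the scatter, but the two differ in several places at once. Compound 3 `O=C1Nc2ccccc2/C1=C\c1c(Cl)n(CCCc2ccccc2)c2ccccc12` differs from compound 1 by phenethyl in place of phenyl on a saturated chain carbon bound to an aromatic nitrogen. Among the compounds with values here, no measured pair isolates this change, so no step size is known for it. The expected step from compound 1 to compound 3 in this assay is a 1.3-fold lower number from compound 1 to compound 3 (0.11 log units; within the scatter), within the scatter. Compound 3 is estimated at 50000 nM, with a range of 15000 nM to 150000 nM.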

Compound 3, concentration for total growth inhibition: 72400 nM
The estimate for compound 3 lay 1.4-fold (0.16 log units) below the measured number, and the stated range covers the measured number.
By their numbers in this assay, from the lowest: compound 2; then compounds 1 and 3 (each within the scatter of the next).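

In this assay, within the data shown here, phenethyl in place of phenyl on a saturated chain carbon bound to an aromatic nitrogen gives a 1.1-fold higher number from compound 1 to compound 3 (0.05 log units; within the scatter), the only step read so far at this place. Benzyl and 3-phenylpropyl are not told apart on the core of compound 1 in this read-out. No data on the cause of this result are at hand.

Open, from the compounds shown here alone, is whether a longer chain, or an amine or carboxylic acid at the end of the chain, would give a step beyond the scatter. Also open, going by these compounds, is what methoxy groups on the phenyl ring alone would do.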